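The source may report more compounds than this note shows. Statements on the series, on what has been measured and on what is new or still open speak of the compounds shown alone.

Measured in a functional assay on MCF7 cells (Homo sapiens) for inhibition, with a stated time of 48 h; a lower number here means a stronger inhibitor, a higher number a weaker inhibitor:
- compound 1 `COc1cc(Sc2c[nH]c3ccc(Br)cc23)cc(OC)c1OC`: 43 nM
- compound 2 `COc1cc(Sc2c[nH]c3ccc([N+](=O)[O-])cc23)cc(OC)c1OC`: 560 nM
- compound 3 `COc1cc(Sc2c[nH]c3ccc(C)cc23)cc(OC)c1OC`: 16 nM

Compound 3 has the lowest number of the three in this assay. Compound 4 `COc1ccc2[nH]cc(Sc3cc(OC)c(OC)c(OC)c3)c2c1` carries methoxy in place of methyl on an aromatic carbon. The measured steps all change the group at this same place. Replacing bromo with methyl gives a 2.7-fold lower number from compound 1 to compound 3 (0.43 log units; beyond the scatter), a modest step, while the two steps involving nitro, a 13-fold higher number from compound 1 to compound 2 (1.11 log units; beyond the scatter) and a 35-fold lower number from compound 2 to compound 3 (1.54 log units; beyond the scatter), are large. None of them involves methoxy, so the direction is uncertain. Since compound 3 already stands lowest at 16 nM, a modest rise is expected in this assay. The expected change is a 1.6-fold higher number from compound 3 to compound 4 (0.19 log units; within the scatter). For compound 4 the estimated value is 25 nM, with an expected range from 8 nM to 80 nM.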

Compound 4, half-maximal inhibitory concentration: 22 nM
Estimate against measurement, compound 4: 1.1-fold (0.06 log units) above, and the stated range covers the measured number.
By their numbers in this assay, from the lowest: compounds 3, 4 and 1 (each within the scatter of the next, the first and the last beyond it); then compound 2.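

In this assay methoxy joins methyl and bromo as a group this position tolerates: a 1.4-fold higher number from compound 3 to compound 4 (0.14 log units; within the scatter) and a 2.0-fold lower number from compound 1 to compound 4 (0.29 log units; within the scatter) both lie within the scatter. By contrast, a 25-fold lower number from compound 2 to compound 4 (1.41 log units; beyond the scatter) is large, so of the four groups shown, only nitro stands apart from the others. No measurement offered here explains why these groups group this way.

The compounds shown leave open how an amine, a carboxylic acid or a longer chain such as ethoxy would fare at this place. They also leave open whether any group here could go clearly beyond methyl and methoxy.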